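Oxygen to sulfur on the carbonyl: compound 4 expected

This account rests on a few compounds, and the source may have more. Where it says the series, first, only, none or still open, it means among the compounds named here.

In an ADME assay on a cell-free system (plasma, Mus musculus) for protein binding, read by LC-MS, with a stated time of 4 h, tested at 5 uM (a higher number here means a larger unbound share of the compound, a lower number a smaller unbound share), compound 3 `O=C(NCc1ccc(S(=O)(=O)c2cccc(C(F)(F)F)c2)cc1)c1cc2ccncc2o1` gives 0.011 and stands within the scatter of compound 1 `O=C(NCc1ccc(S(=O)(=O)c2cccc(C(F)(F)F)c2)cc1)c1cc2cnccc2[nH]1` at 0.007 while compound 2 `O=C(NCc1ccc(S(=O)(=O)c2cc(F)cc(F)c2)cc1)c1cnc2nccn2c1` at 0.133 lies beyond the scatter on the high side. Compound 4 `O=C(NCc1ccc(S(=O)(=O)c2cccc(C(F)(F)F)c2)cc1)c1cc2ccncc2s1` carries a single change from compound 3: a group of 9 heavy atoms (7 carbon, 1 nitrogen, 1 sulfur; one five-membered aromatic ring with 1 hetero atom, one six-membered aromatic ring with 1 hetero atom) in place of a group of 9 heavy atoms (7 carbon, 1 nitrogen, 1 oxygen; one five-membered aromatic ring with 1 hetero atom, one six-membered aromatic ring with 1 hetero atom), on a carbonyl carbon with sulfur taking the place of oxygen. For the measured compounds named here, only one measured step falls on that carbonyl carbon, a 1.6-fold higher number from compound 1 to compound 3 (0.20 log units; within the scatter) and it stayed within the scatter. Going by the values given here, no measured step shows what sulfur does here, so no shift beyond the scatter is expected. The expected step is a 1.4-fold lower number from compound 3 to compound 4 (0.14 log units; within the scatter) and it stays within the scatter. Compound 4 is estimated at 0.008 with a range from 0.004 to 0.016 as its expected span.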

Compound 4, unbound fraction: 0.002
The estimate for compound 4 lay 4.0-fold (0.60 log units) above the measured number; the whole stated range lies above it.
By their numbers in this assay, from the lowest: compound 4; then compounds 1 and 3 (each within the scatter of the next); then compound 2.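

At this carbonyl carbon, the earlier step stayed within the scatter, but the group choice proved able to move the unbound fraction in this assay: the sulfur-containing group in place of the oxygen-containing group gave a 5.5-fold lower number from compound 3 to compound 4 (0.74 log units; beyond the scatter). Against the group with two nitrogens, it gave a 3.5-fold lower number from compound 1 to compound 4 (0.54 log units; beyond the scatter). Nothing measured here accounts for this drop. The compounds shown leave open whether the sulfur step holds alongside the sulfonyl partner of compound 2, and what an amine or a carboxylic acid on this group would do.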